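Swapping trifluoromethyl for carbamoyl: expected cytotoxicity of compound 4

The source may hold more compounds than are shown below. What is called first, only, known or untested is meant among the compounds shown, and "the series" means these compounds.

Measured so far:
- compound 1, `Cc1cc(NC(=O)Nc2ccccc2C(F)(F)F)c2ccccc2n1`: > 25000 nM
- compound 2, `Cc1cc(NC(=O)Nc2cccc(C(F)(F)F)c2)c2ccccc2n1`: 16000 nM
- compound 3, `Cc1cc(NC(=O)Nc2ccc(Cl)cc2)c2ccccc2n1`: > 25000 nM

In an ADME assay on HEK293 cells (Homo sapiens) for cytotoxicity, with a stated time of 72 h (on this read-out lower numbers stand for an effect already at smaller amounts and higher numbers for an effect only at larger amounts of compound), compound 1 reaches only a limit of the assay, > 25000 nM, and not a number. Compound 3 likewise reaches only the limit, > 25000 nM. Compound 2 gives a number, 16000 nM, in this assay. Two of the three values thus sit at the limit of > 25000 nM in this assay, at which 2 of the 3 values shown sit, so compound 1 stands among the compounds for which no effect was seen within the range tested.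

Compound 4, `Cc1cc(NC(=O)Nc2ccccc2C(N)=O)c2ccccc2n1`, has not yet been measured in this assay. It differs from compound 1 in one place: carbamoyl in place of trifluoromethyl on an aromatic carbon. Among the compounds with values here, no step between two measured compounds covers such a change, so the expected step rests on compound 1 alone, and no step beyond the usual scatter is expected in this assay in either direction.

The expected step from compound 1 to compound 4 is a step that the limit leaves unreadable from compound 1 to compound 4. Compound 4 is therefore expected to give about 30000 nM in this assay, between 12000 nM and 80000 nM, most likely reported again only as a limit.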

Compound 4, half-maximal effective concentration: > 25000 nM
Compound 4 was reported as a limit (the forecaster's own chance of this, stated with the estimate: 70%); the middle value does not contradict the limit.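

Compound 1 and compound 4 both reach only a limit of this assay, not a number, so no step can be read for carbamoyl in place of trifluoromethyl: the limit of > 25000 nM in this assay, at which 3 of the 4 values shown sit. The compounds shown leave open where the true values of compound 1 and compound 4 lie, and so whether this swap shifts cytotoxicity at all.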